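The compounds below may be only part of what the source reports. "The series", "measured", "known", "first", "only" and "open" are said of these compounds alone.

Three amides on the shared core have numbers in an assay on isolated protein for inhibition of aldehyde dehydrogenase 1A1 (Homo sapiens), read by spectrophotometry, tested at 10 uM; on this read-out lower numbers stand for less inhibition and higher numbers for more inhibition at the one concentration tested (going by the name of the read-out). Compound 1 `Cc1cccc(Cn2c(CN3CCN(C(=O)c4cccs4)CC3)nc3ccccc32)c1` gives 60.8%; compound 2 `Cc1cccc(Cn2c(CN3CCN(C(=O)c4ccc(Cl)cc4)CC3)nc3ccccc32)c1` gives 23.2%; compound 3 `Cc1cccc(Cn2c(CN3CCN(C(=O)C(C)C)CC3)nc3ccccc32)c1` gives 87.2%, the highest of the three, with the steps of a number 26.4 percentage points higher from compound 1 to compound 3 (beyond the scatter) and a number 64 percentage points higher from compound 2 to compound 3 (beyond the scatter) both beyond the scatter, as is a number 37.6 percentage points lower from compound 1 to compound 2 (beyond the scatter). Compound 4 `Cc1cccc(Cn2c(CN3CCN(C(=O)c4ccc(F)cc4)CC3)nc3ccccc32)c1` differs from compound 3 by 4-fluorophenyl in place of isopropyl on a carbonyl carbon. The step from compound 2 to compound 3 bears on this most closely: 4-chlorophenyl and 4-fluorophenyl differ only in the halogen, and the step from compound 1 to compound 3 points the same way, an aromatic ring on the carbonyl carbon standing lower than isopropyl. A large drop is therefore expected, a number 57.2 percentage points lower from compound 3 to compound 4 (beyond the scatter). Compound 4 is estimated at 30%, within 10% to 58%.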

Compound 4, a percentage reported as inhibition, at one concentration (the size of the read-out at that concentration, not a potency): 27.1%
For compound 4 the middle estimate is 2.9 percentage points above the measured one, within the range that was stated.
By their numbers in this assay, from the lowest: compounds 2 and 4 (each within the scatter of the next); then compound 1; then compound 3.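

In this assay, 4-fluorophenyl and 4-chlorophenyl on the carbonyl carbon read alike, with a number 3.9 percentage points higher from compound 2 to compound 4 (within the scatter), so the low numbers are not tied to chloro alone. Both the loss against isopropyl, a number 60.1 percentage points lower from compound 3 to compound 4 (beyond the scatter), and the loss against thiophen-2-yl, a number 33.7 percentage points lower from compound 1 to compound 4 (beyond the scatter), go with a halogen-bearing phenyl ring, while thiophen-2-yl, though also aromatic, stands apart from both halogen-bearing compounds. Nothing available here accounts for these differences.

Open, going by these compounds, is whether cyclopropyl or tert-butyl on the carbonyl carbon keeps the number of compound 3, and where an unsubstituted phenyl ring would stand.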